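Trimming a Methoxy from the Dimethoxyphenyl Ketone

The source may hold more compounds than are shown below. What is called first, only, known or untested is meant among the compounds shown, and "the series" means these compounds.

Among the measured compounds shown here, compound 2 `COc1ccc(C(=O)/C=C/c2cc(-c3cc(OC)c(OC)c(OC)c3)n[nH]2)cc1OC` stands highest of the two numbers so far in a functional assay on A498 cells (Homo sapiens) for cytotoxicity, read by sulforhodamine B assay, with a stated time of 48 h, tested at 0.01 uM (on this read-out lower numbers stand for a stronger effect and higher numbers for a weaker effect at the one concentration tested), where compound 2 gives 97%. For the measured compounds named here, its nearest neighbour is compound 1 `COc1cc(-c2cc(/C=C/C(=O)c3ccc(Cl)c(Cl)c3)[nH]n2)cc(OC)c1OC`, which in this assay gives 84%; the one measured step, a number 13 percentage points higher from compound 1 to compound 2 (beyond the scatter), exchanged the group on the carbonyl carbon.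

Compound 3 `COc1ccc(C(=O)/C=C/c2cc(-c3cc(OC)c(OC)c(OC)c3)n[nH]2)cc1` is the compound still to be measured. It differs from compound 2 by hydrogen in place of methoxy on an aromatic carbon, on an aromatic carbon of a six-membered aromatic ring of carbon only, ortho to a methoxy group and meta to a large group; cut one bond further out this reads 3,4-dimethoxyphenyl to 4-methoxyphenyl.

Going by the values given here, only the step from compound 1 to compound 2 touches this ring, and it concerned a different exchange, so it bears on the present change only loosely. Because a number 13 percentage points higher from compound 1 to compound 2 (beyond the scatter) was modest and compound 2 already sits near the top of the scale, the expected step of a number 5 percentage points lower from compound 2 to compound 3 (within the scatter) is small, at most a slight drop and possibly none beyond the scatter. Compound 3 is therefore estimated at 92% in this assay, with a range from 78% to 104%.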

Compound 3, a percentage reported as activity, at one concentration (the size of the read-out at that concentration, not a potency): 98%
Compound 3: the middle estimate sits 6 percentage points below what was measured; low and high end bracket the measured number.
By their numbers in this assay, from the lowest: compound 1; then compounds 2 and 3 (each within the scatter of the next).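

In this assay, putting hydrogen in place of methoxy on the aromatic carbon ortho to a methoxy group and meta to a large group gave a number 1 percentage points higher from compound 2 to compound 3 (within the scatter), so at this single concentration the read-out does not distinguish 3,4-dimethoxyphenyl from 4-methoxyphenyl on the carbonyl carbon. The exchange of 3,4-dichlorophenyl for 4-methoxyphenyl gave a number 14 percentage points higher from compound 1 to compound 3 (beyond the scatter), a step of about the same size as a number 13 percentage points higher from compound 1 to compound 2 (beyond the scatter), so among these three compounds the only differences beyond the scatter are those separating compound 1 from the two methoxy-bearing compounds. Nothing measured here offers an explanation for these steps.

With compound 2 at 97% and compound 3 at 98%, this one concentration leaves open whether the extra methoxy group would matter in a full concentration series or in other cell lines. It also leaves open what a hydroxyl group, a chlorine atom or an amine would do on the same aromatic carbon, and whether a single chlorine on the 4-methoxyphenyl group's para carbon would bring the number toward that of compound 1.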